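Adding a second chloro to the core of compound 2

The source may hold more compounds than are shown below. What is called first, only, known or untested is meant among the compounds shown, and "the series" means these compounds.

Measured compounds:
compound 1 `ClCc1ccc(Cn2cnc3nc(Cl)nc(Cl)c32)cc1` — 8910 nM
compound 2 `ClCc1ccccc1Cn1cnc2ncnc(Cl)c21` — 49000 nM

In a functional assay on NCI-H23 cells (Homo sapiens) for cytotoxicity, read by sulforhodamine B assay, with a stated time of 48 h (a higher number here means that more compound is tolerated, a lower number that less compound is tolerated), compound 2 stands highest of the two numbers shown; the nearest, compound 1, gives a number that is lower by more than the usual scatter. The step to compound 3 `ClCc1ccccc1Cn1cnc2nc(Cl)nc(Cl)c21` is chloro in place of hydrogen on an aromatic carbon, between two ring nitrogen atoms. Among the measured compounds shown here, no pair of measured compounds that differ only in this way is available, so the size of the step can only be judged from what compound 1 and compound 2 show, and compound 1, which carries two chloro groups on its core, is the more cytotoxic of the two. The expected step in this assay from compound 2 to compound 3 is therefore downward, beyond the scatter, estimated at a 4.1-fold lower number from compound 2 to compound 3 (0.61 log units; beyond the scatter). Compound 3 is expected to give about 12000 nM, in a range from 4000 nM to 40000 nM.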

Compound 3, concentration lethal to 50% of the cells: 87100 nM
For compound 3 the middle estimate is 7.3-fold (0.86 log units) below the measured one; measured number above the stated range.
By their numbers in this assay, from the lowest: compound 1; then compounds 2 and 3 (each within the scatter of the next).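

In this assay, chloro in place of hydrogen on an aromatic carbon, between two ring nitrogen atoms, gives a 1.8-fold higher number from compound 2 to compound 3 (0.25 log units; within the scatter), so this single change leaves the number unmoved as far as the assay can tell. Compound 3 gives 87100 nM while compound 1, with the same two chloro groups on its core, gives 8910 nM, so the second chloro does not by itself bring a compound to the number of compound 1. Nothing measured here explains why this position tolerates the change.

The compounds shown leave open whether a different group at this position, such as an amine or a methoxy group, would shift the number beyond the scatter. Compound 1 and compound 3 differ in where the chloromethyl group sits. The compounds shown do not tell what that difference does to the number.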